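Swapping the Ring Amine on a Fused Core

A few compounds are considered here, and "the series" means these few. Any claim that something is new, unique, unknown or untested is made for them only; others in the source may bear on it.

In an assay on cells for displacement of a labelled ligand from adenosine receptor A3 (Homo sapiens), read by scintillation counting and radioligand binding, with a stated time of 180 min (on this read-out lower numbers stand for stronger inhibition and higher numbers for weaker inhibition), compound 1 `CN1CCN(c2nc(-c3ccc(Cl)c(Cl)c3)nc3[nH]cnc23)CC1` gives 39.8 nM, and compound 2 `CN1CCN(c2nc(-c3cccc(Cl)c3)nc3[nH]cnc23)CC1` gives 100 nM; the step of a 2.5-fold higher number from compound 1 to compound 2 (0.40 log units; beyond the scatter) comes from a change on the aryl group, not on the ring amine. In this assay compound 3 `Oc1cccc(-c2nc(N3CCCCC3)c3nc[nH]c3n2)c1` gives 63.1 nM, the second highest of the three numbers, within the scatter of both compound 2 and compound 1. Compound 4 `CN1CCN(c2nc(-c3cccc(O)c3)nc3[nH]cnc23)CC1` differs from compound 3 by 4-methylpiperazin-1-yl in place of piperidin-1-yl on an aromatic carbon. Going by the values given here, no measured step follows this swap directly, yet compound 1 with 39.8 nM and compound 2 with 100 nM already carry the 4-methylpiperazin-1-yl group and sit within the scatter of compound 3, so a shift beyond the scatter is not expected. Compound 4 is therefore estimated at 63 nM, between 20 nM and 200 nM. The expected step is a 1.0-fold lower number from compound 3 to compound 4 (0.00 log units; within the scatter).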

Compound 4, inhibition constant: 501 nM
Compound 4: the middle estimate sits 8.0-fold (0.90 log units) below what was measured; measured number above the stated range.
By their numbers in this assay, from the lowest: compounds 1, 3 and 2 (each within the scatter of the next, the first and the last beyond it); then compound 4.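

In this assay, going by these compounds alone, the ring amine proves to matter on this core, which no earlier pair could show: 4-methylpiperazin-1-yl in place of piperidin-1-yl gives a 7.9-fold higher number from compound 3 to compound 4 (0.90 log units; beyond the scatter) with the 3-hydroxyphenyl group kept. The aryl group counts as well, since hydroxy in place of chloro gives a 5.0-fold higher number from compound 2 to compound 4 (0.70 log units; beyond the scatter) and 3-hydroxyphenyl in place of 3,4-dichlorophenyl gives a 13-fold higher number from compound 1 to compound 4 (1.10 log units; beyond the scatter) with the same amine kept. Nothing measured here explains these steps. As far as these compounds go, whether piperidin-1-yl would give a similar step beside a chlorinated aryl group stays open. So does how a morpholine ring or an open-chain amine such as dimethylamino would read at this position.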